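The compounds below may be only part of what the source reports. "The series", "measured", "known", "first", "only" and "open" are said of these compounds alone.

Working notes on the series. In an ADME assay for permeability, using PAMPA, with a stated time of 30 min, at pH 7.4 (a higher number here means that the compound crosses the layer faster, a lower number that the compound crosses the layer more slowly), compound 1 `COc1ccc(-c2ccc3c(NCCCNCc4cccc(OC)c4O)ccnc3c2)cc1` gives 237 10^-6 cm/s and compound 3 `COc1ccc(-c2ccc3c(NCCCNCc4ccco4)ccnc3c2)cc1` gives 237 10^-6 cm/s; the two stand together as the highest of the three numbers, with no change at the digits printed from compound 1 to compound 3 (within the scatter) for the change at the chain carbon bound to the amine nitrogen. Going by the values given here, compound 2 `CC(C)CCc1ccc2c(NCCCNCc3ccco3)ccnc2c1` gives 23 10^-6 cm/s in this assay, the furthest from compound 1, and the one step at the aromatic carbon of the core, a 10-fold higher number from compound 2 to compound 3 (1.01 log units; beyond the scatter), is large. Compound 4 `COc1ccc(Oc2ccc3c(NCCCNCc4cccc(OC)c4O)ccnc3c2)cc1` carries 4-methoxyphenoxy in place of 4-methoxyphenyl on an aromatic carbon. Among the compounds with values here, only the step from compound 2 to compound 3 touches this position, and it swapped a chain for a ring; here the ring stays and an oxygen enters, so a step of a 1.3-fold lower number from compound 1 to compound 4 (0.12 log units; within the scatter) within or near the scatter is expected. For compound 4 the expected value in this assay is 180 10^-6 cm/s, between 90 10^-6 cm/s and 320 10^-6 cm/s.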

Compound 4, apparent permeability: 317 10^-6 cm/s
The estimate for compound 4 lay 1.8-fold (0.25 log units) below the measured number, within the range that was stated.
By their numbers in this assay, from the lowest: compound 2; then compounds 1, 3 and 4 (each within the scatter of the next).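

With this assay as the read-out, 4-methoxyphenoxy in place of 4-methoxyphenyl gives a 1.3-fold higher number from compound 1 to compound 4 (0.13 log units; within the scatter), so this aromatic carbon tolerates the extra oxygen with the ring kept. Going by these compounds alone, the only earlier step here, a 10-fold higher number from compound 2 to compound 3 (1.01 log units; beyond the scatter), exchanged isopentyl for a ring and could not show this. No evidence on the cause of this result is at hand. The compounds shown leave open how an amine or a carboxylic acid at this aromatic carbon would read, and whether 4-methoxyphenoxy behaves alike with furan-2-yl on the chain.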